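A few compounds are considered here, and "the series" means these few. Any claim that something is new, unique, unknown or untested is made for them only; others in the source may bear on it.

Among the compounds with values here, compound 2 `Clc1ccc2oc(SCCCN3CCCC3)nc2c1` gives 10.4 mL/min/g in an ADME assay on microsomes from liver (Mus musculus) for metabolic stability, read by LC-MS, using NADPH, with a stated time of 45 min, tested at 0.5 uM; on this read-out lower numbers stand for slow clearance and higher numbers for fast clearance; it holds the lowest of the two numbers so far, with compound 1 `O=C(CCSc1nc2cc(Cl)ccc2o1)N1CCC1` nearest at 17.9 mL/min/g in this assay. Compound 3 `O=S1(=O)CCCN1CCCSc1nc2cc(Cl)ccc2o1` is the next point in the series and has not yet been measured. The change from compound 2 is a group of 7 heavy atoms (3 carbon, 1 nitrogen, 2 oxygen, 1 sulfur; one five-membered non-aromatic ring with 2 hetero atoms) in place of a group of 5 heavy atoms (4 carbon, 1 nitrogen; one five-membered non-aromatic ring with 1 hetero atom), on a saturated chain carbon, three bonds along the chain from a sulfur. Within the data shown here, only one measured step exists: a 1.7-fold lower number from compound 1 to compound 2 (0.24 log units; within the scatter). It concerns a different pair of groups, exchanged on a saturated chain carbon two bonds along the chain from a sulfur, and bears on the new change only in showing that an exchange of the group on the chain has not moved the number beyond the scatter. Among the measured compounds shown here, no measured pair exchanges the five-membered ring with one hetero atom for the five-membered ring with two hetero atoms, so a direct precedent is absent. The step from compound 2 to compound 3 is therefore expected to be a 1.2-fold lower number from compound 2 to compound 3 (0.06 log units; within the scatter), none beyond the scatter. Compound 3 is estimated at 9 mL/min/g, with a range from 4 mL/min/g to 20 mL/min/g.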

Compound 3, intrinsic clearance in a liver preparation (reported as CLH), per the amount of preparation that the assay uses: 115 mL/min/g
Estimate against measurement, compound 3: 13-fold (1.11 log units) below, outside the stated range (above it).
By their numbers in this assay, from the lowest: compounds 2 and 1 (each within the scatter of the next); then compound 3.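

In this assay, within the data shown here, the five-membered non-aromatic ring with 2 hetero atoms in place of pyrrolidin-1-yl gives an 11-fold higher number from compound 2 to compound 3 (1.04 log units; beyond the scatter) and is the first step beyond the scatter, while the earlier exchange on the chain, a 1.7-fold lower number from compound 1 to compound 2 (0.24 log units; within the scatter), stayed within it. The group on a saturated chain carbon, three bonds along the chain from a sulfur, is thus a place where a single exchange can move this clearance read-out by a large amount, which the earlier pair gave no sign of. Nothing measured here bears on what lies behind this rise.

The two rings differ in more than one feature, so the compounds shown do not tell which feature of the entering group goes with the higher number; a pyrrolidin-2-one or a morpholine attached through its nitrogen at the same place would help to separate them. Also open, on these data alone, is whether the same exchange gives a step of similar size on the chain of compound 1, or with a core other than the shared one.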